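The source may report more compounds than this note shows. Statements on the series, on what has been measured and on what is new or still open speak of the compounds shown alone.

Compounds measured so far in this series:

Compound 1, `CNC(=O)[C@H](c1ccc(Cl)cc1)C(C)C`, gives 11000 nM in a functional assay on CHO cells for agonist activity at Free fatty acid receptor 2 (Homo sapiens), read by cAMP accumulation; a lower number here means a stronger inhibitor, a higher number a weaker inhibitor.
Compound 2, `CC(C)[C@H](C(=O)Nc1ccccc1)c1ccc(Cl)cc1`, reaches only the limit of this assay, > 100000 nM, and so has no number.
Compound 3, `CC(C)[C@H](C(=O)Nc1ccccn1)c1ccc(Cl)cc1`, gives 1400 nM in this assay.

For the measured compounds named here, compound 3 therefore stands lowest of the two numbers known; the nearest is compound 1, the step being a 7.9-fold lower number from compound 1 to compound 3 (0.90 log units; beyond the scatter). The remaining value is the limit (the limit of > 100000 nM in this assay, at which 1 of the 3 values shown sits).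

Compound 4, `CC(C)[C@H](C(=O)Nc1ccc(F)cn1)c1ccc(Cl)cc1`, is the next case. It differs from compound 3 by fluoro in place of hydrogen on an aromatic carbon; the pyridin-2-yl on the amide nitrogen and the rest of the shared core are kept.

The three measured steps all swap the whole group on the amide nitrogen: an at least 9.0-fold higher number from compound 1 to compound 2 (0.95 log units; beyond the scatter), a 7.9-fold lower number from compound 1 to compound 3 (0.90 log units; beyond the scatter) and an at least 71-fold lower number from compound 2 to compound 3 (1.85 log units; beyond the scatter). None of them puts fluoro in place of hydrogen on a ring, so they do not bear directly on this change; they only show that the amide substituent is where large moves have been seen. A single fluoro on a retained ring is expected to give a step within the scatter, or at most a modest one, in either direction.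

Compound 4 is therefore estimated at 1100 nM in this assay, within 400 nM to 3500 nM. The expected step is a 1.3-fold lower number from compound 3 to compound 4 (0.10 log units; within the scatter).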

Compound 4, half-maximal inhibitory concentration: 1300 nM
Compound 4: the middle estimate sits 1.2-fold (0.07 log units) below what was measured; the measured number falls inside the stated range.
By their numbers in this assay, from the lowest: compounds 4 and 3 (each within the scatter of the next); then compound 1. At a limit, above all of these: compound 2.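

In this assay, for the compounds shown here, this is the first change on the retained ring rather than a swap of the whole group on the amide nitrogen, and fluoro in place of hydrogen, two atoms from the ring nitrogen and para to a large group, gives a step within the scatter: a 1.1-fold lower number from compound 3 to compound 4 (0.03 log units; within the scatter). The 5-fluoropyridin-2-yl group therefore keeps the standing that pyridin-2-yl has over the other two amide substituents, with an 8.5-fold lower number from compound 1 to compound 4 (0.93 log units; beyond the scatter) and an at least 76-fold lower number from compound 2 to compound 4 (1.88 log units; beyond the scatter). The second of these steps rests on compound 2, whose value is a limit of the assay and not a number.

No measurement shown gives a cause for this result. Still open, going by these compounds, is whether this ring position accepts anything larger than fluoro, such as a methoxy group, an amine or a carboxylic acid, or whether the flat step holds only for fluoro, and whether fluoro elsewhere on the pyridin-2-yl ring gives a similar step.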